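The source may hold more compounds than are shown below. What is called first, only, known or untested is meant among the compounds shown, and "the series" means these compounds.

Measured so far in the series:

compound 1, `CCCOC(=O)c1ccc(S(N)(=O)=O)cc1`, 1.75 in a physicochemical assay for lipophilicity; a lower number here means a more polar compound, a higher number a more lipophilic compound
compound 2, `CCCCCCOC(=O)c1ccc(S(N)(=O)=O)cc1`, 3.23 in this assay

Compound 1 stands lowest of the two numbers; the nearest to it is compound 2, reached by a number 1.48 log units higher from compound 1 to compound 2 (beyond the scatter). That step is the only one recorded, and it concerns the length of the ester chain alone.

The next compound to be run is compound 3, `CNC(=O)c1ccc(S(N)(=O)=O)cc1`. Compared with compound 1 the change is methylamino in place of propoxy on a carbonyl carbon. Within the data shown here, no measured step touches an exchange of the group on the carbonyl carbon; the step from compound 1 to compound 2 shows only that lengthening the saturated chain moves the number upward by a large margin, and the present change goes the other way in chain length while also swapping the atom that joins the chain to the carbonyl. On that basis a downward step beyond the scatter is expected for compound 3, of roughly a number 2.25 log units lower from compound 1 to compound 3 (beyond the scatter). Compound 3 is estimated at -0.5, with a likely range from -1.1 to 0.1.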

Compound 3, partition coefficient: -0.31
For compound 3 the middle estimate is 0.19 log units below the measured one; the measured number falls inside the stated range.
By their numbers in this assay, from the lowest: compound 3; then compound 1; then compound 2.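

Among these compounds, with methylamino in place of propoxy on the carbonyl carbon, the number in this assay falls by a large margin (a number 2.06 log units lower from compound 1 to compound 3 (beyond the scatter)), the first downward step and the first change at this carbonyl carbon. The earlier step (a number 1.48 log units higher from compound 1 to compound 2 (beyond the scatter)) varied only the length of the saturated chain on the ester oxygen, whereas this one shows that the group on the carbonyl carbon can move the number a long way while the core of compound 1 stays the same. The exchange replaces propoxy, with 4 heavy atoms and 1 hydrogen-bond acceptor, by methylamino, with 2 heavy atoms and 1 hydrogen-bond donor, and nothing at hand explains the size of the step.

Chain length and the atom joining the chain to the carbonyl change together here, so the step cannot yet be divided between them. Propylamino or methoxy on the same carbonyl carbon would separate the two contributions, and a carboxylic acid there would extend the comparison to a further group.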